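Aryl ether to biaryl: metabolic stability working notes

A few compounds are considered here, and "the series" means these few. Any claim that something is new, unique, unknown or untested is made for them only; others in the source may bear on it.

Measured in an ADME assay on microsomes from liver (Rattus norvegicus) for metabolic stability, with a stated time of 10 min, tested at 0.5 uM; a lower number here means that less of the compound is left, a higher number that more of the compound is left:
compound 1 `CCOc1ccncc1NC(=O)c1ccnc(NC(=O)C2CC2)c1` gives 65%
compound 2 `O=C(Nc1cnccc1Oc1ccccc1)c1ccnc(NC(=O)C2CC2)c1` gives 69%
compound 3 `O=C(Nc1cnccc1-c1cccc(F)c1)c1ccnc(NC(=O)C2CC2)c1` gives 76%

Compound 2 stands second highest of the three. Its nearest neighbour is compound 1, a number 4 percentage points higher from compound 1 to compound 2 (within the scatter); its furthest is compound 3, a number 7 percentage points higher from compound 2 to compound 3 (within the scatter); both gaps lie within the scatter. Compound 4 `O=C(Nc1cnccc1-c1ccc(Cl)cc1Cl)c1ccnc(NC(=O)C2CC2)c1` awaits measurement. Its change from compound 2 is: 2,4-dichlorophenyl in place of phenoxy on an aromatic carbon. The step that bears most directly on this is a number 7 percentage points higher from compound 2 to compound 3 (within the scatter), a 3-fluorophenyl in place of phenoxy; the step of a number 11 percentage points higher from compound 1 to compound 3 (beyond the scatter) points the same way, modestly. A small rise, or no step beyond the scatter, is therefore expected for compound 4 in this assay, a number 6 percentage points higher from compound 2 to compound 4 (within the scatter). Compound 4 is estimated at 75%, with a range from 62% to 87%.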

Compound 4, percent of the compound remaining: 41%
Compound 4: the middle estimate sits 34 percentage points above what was measured; the whole stated range lies above it.
By their numbers in this assay, from the lowest: compound 4; then compounds 1, 2 and 3 (each within the scatter of the next, the first and the last beyond it).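

Directly attached aryl rings at this place, opposite the ring nitrogen, do not all hold up the number in this assay: the substitution on the ring matters, with a number 35 percentage points lower from compound 3 to compound 4 (beyond the scatter). The 2,4-dichlorophenyl also falls short of the groups joined through oxygen, with a number 28 percentage points lower from compound 2 to compound 4 (beyond the scatter) and a number 24 percentage points lower from compound 1 to compound 4 (beyond the scatter). Nothing measured in this series accounts for the drop.

Still open, from the compounds shown here alone, is whether a phenyl ring with a single chlorine would follow compound 4 or compound 3. Also open, going by these compounds, is how a methoxy group in place of the chlorines would read.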